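Swapping bromo for methyl on a sulfonamide aryl ring

The source may report more compounds than this note shows. Statements on the series, on what has been measured and on what is new or still open speak of the compounds shown alone.

Compound 1 `O=S(=O)(Nc1ccc2cc[nH]c2c1)c1ccc(Br)cc1` carries a bromo group on a six-membered aromatic ring of carbon only, joined through a sulfonamide to the shared core. In a functional assay on T47D cells (Homo sapiens) for antiproliferative activity, read by MTT assay, with a stated time of 24 h (a lower number here means a stronger inhibitor, a higher number a weaker inhibitor), compound 1 gives 40100 nM. Two close relatives have been measured in the same test. Compound 2 `O=C(Nc1ccc2cc[nH]c2c1)c1ccc(Br)cc1`, in which an amide replaces the sulfonamide, gives 63700 nM, and compound 3 `COc1ccc(S(=O)(=O)Nc2ccc3cc[nH]c3c2)cc1`, which keeps the sulfonamide but carries methoxy in place of bromo on an aromatic carbon, gives 45000 nM. The three numbers sit within the usual scatter of one another, so none of the compounds can be set apart from the rest.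

Compound 4 `Cc1ccc(S(=O)(=O)Nc2ccc3cc[nH]c3c2)cc1` has not yet been measured. It differs from compound 1 in one place: methyl in place of bromo on an aromatic carbon. Going by the values given here, the only measured step that bears on this change is a 1.1-fold higher number from compound 1 to compound 3 (0.05 log units; within the scatter), where a different small group also replaced bromo on the same aromatic carbon. That step stayed within the scatter, so a move from bromo to methyl is expected to produce no step beyond the scatter in this assay, in either direction. For compound 4 the expected step is a 1.0-fold higher number from compound 1 to compound 4 (0.02 log units; within the scatter). Compound 4 is therefore estimated at 42000 nM, with a likely range from 20000 nM to 90000 nM.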

Compound 4, half-maximal inhibitory concentration: 57100 nM
Compound 4: the middle estimate sits 1.4-fold (0.13 log units) below what was measured, and the stated range covers the measured number.
By their numbers in this assay, from the lowest: compounds 1, 3, 4 and 2 (each within the scatter of the next).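

With methyl now on this aromatic carbon, para to a large group, three groups have been compared at one place on the sulfonamide compounds in this assay: going from bromo to methyl gives a 1.4-fold higher number from compound 1 to compound 4 (0.15 log units; within the scatter) and going from methoxy to methyl gives a 1.3-fold higher number from compound 3 to compound 4 (0.10 log units; within the scatter) and so neither change moves the number beyond the scatter. Going by these compounds alone, the earlier compounds offered only one change at this carbon, whereas bromo, methoxy and methyl can now be compared in all pairs, and this test does not separate any of them, even though bromine, a carbon and an oxygen-linked group each make the attachment here. Nothing among the data shown explains why these compounds read alike.

As far as these compounds go, whether an amine, a carboxylic acid or a longer chain on this same carbon would give a step beyond the scatter remains open. Compound 2 is the only amide shown and it carries bromo, so it also remains open whether methyl or methoxy would read the same way on the amide.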